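Halogen to hydrogen on the fused ring: what to expect

A few compounds are considered here, and "the series" means these few. Any claim that something is new, unique, unknown or untested is made for them only; others in the source may bear on it.

Two compounds have been measured in a functional assay on DU-145 cells (Homo sapiens) for cytotoxicity, read by MTT assay, with a stated time of 48 h; on this read-out lower numbers stand for stronger inhibition and higher numbers for weaker inhibition:
compound 1, `COc1ccc(-c2cc(C(=O)Nc3nc4ccc(Cl)cc4s3)nc3cc(-c4ccccc4)nn23)cc1`, with 5880 nM;
compound 2, `COc1ccc(-c2cc(C(=O)Nc3nc4ccc(F)cc4s3)nc3cc(-c4ccccc4)nn23)cc1`, with 31400 nM.

Compound 2 stands highest of these two numbers; its nearest neighbour is compound 1, reached by a 5.3-fold higher number from compound 1 to compound 2 (0.73 log units; beyond the scatter). Compound 3, `COc1ccc(-c2cc(C(=O)Nc3nc4ccccc4s3)nc3cc(-c4ccccc4)nn23)cc1`, differs from compound 2 by hydrogen in place of fluoro on an aromatic carbon. For the measured compounds named here, the only step that bears on this change is a 5.3-fold higher number from compound 1 to compound 2 (0.73 log units; beyond the scatter), a modest rise when chloro became fluoro. Removing the last halogen is expected to give a small rise in this assay, if anything beyond the scatter. Compound 3 is therefore estimated at 40000 nM, between 12000 nM and 130000 nM, which is expected to mean a 1.3-fold higher number from compound 2 to compound 3 (0.11 log units; within the scatter).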

Compound 3, half-maximal inhibitory concentration: 2950 nM
Estimate against measurement, compound 3: 14-fold (1.13 log units) above; measured number outside the range, below it.
By their numbers in this assay, from the lowest: compounds 3 and 1 (each within the scatter of the next); then compound 2.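

In this assay, replacing fluoro with hydrogen on the aromatic carbon is a large step (an 11-fold lower number from compound 2 to compound 3 (1.03 log units; beyond the scatter)), so a falling halogen size does not simply carry the number further upward. Hydrogen and chloro at this place cannot be told apart (a 2.0-fold lower number from compound 1 to compound 3 (0.30 log units; within the scatter)), which leaves fluoro as the only one of the three groups that stands apart. Nothing available explains why fluoro differs here.

The compounds shown leave open how a bromo, a methyl or an amine at this place would compare with hydrogen and chloro.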